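Methoxy for Fluoro on the Benzyl Side Chain

The source may hold more compounds than are shown below. What is called first, only, known or untested is meant among the compounds shown, and "the series" means these compounds.

Compound 1, `Nc1cc(N)c2nc(-c3ccccc3)c(NCc3ccc(Cl)c(Cl)c3)nc2c1`, gives 2090 nM in a functional assay on U-251 cells (Homo sapiens) for inhibition, read by sulforhodamine B assay, with a stated time of 48 h; a higher number here means a weaker inhibitor of growth, a lower number a stronger inhibitor of growth.
Compound 2, `COc1ccc(CNc2nc3cc(N)cc(N)c3nc2-c2ccccc2)cc1OC`, gives 17000 nM.
Compound 3, `Nc1cc(N)c2nc(-c3ccccc3)c(NCc3ccc(F)cc3)nc2c1`, gives 1580 nM.

Compound 3 has the lowest number of the three, but the step of a 1.3-fold lower number from compound 1 to compound 3 (0.12 log units; within the scatter) lies within the scatter, so no order between these two compounds can be read. Only compound 2 stands apart, as an 11-fold lower number from compound 2 to compound 3 (1.03 log units; beyond the scatter) shows.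

Compound 4, `COc1ccc(CNc2nc3cc(N)cc(N)c3nc2-c2ccccc2)cc1`, differs from compound 3 by methoxy in place of fluoro on an aromatic carbon. Within the data shown here, no measured step changes this one group alone. Among the measured compounds shown here, two steps bear on it: an 8.1-fold higher number from compound 1 to compound 2 (0.91 log units; beyond the scatter) and an 11-fold lower number from compound 2 to compound 3 (1.03 log units; beyond the scatter), both beyond the scatter and both pointing the same way, with the dimethoxy compound weakest. Compound 4 carries one of the two methoxy groups of compound 2 and lacks the other, so it is expected to sit between compound 3 and compound 2, closer to compound 3, with a modest but real rise in number. The expected step is a 3.2-fold higher number from compound 3 to compound 4 (0.50 log units; beyond the scatter). Compound 4 is therefore estimated at 5000 nM, with a range from 2000 nM to 13000 nM.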

Compound 4, concentration for 50% growth inhibition: 13500 nM
Estimate against measurement, compound 4: 2.7-fold (0.43 log units) below; the measured number lies above the stated range.
By their numbers in this assay, from the lowest: compounds 3 and 1 (each within the scatter of the next); then compounds 4 and 2 (each within the scatter of the next).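

In this assay, among these compounds, the one change of fluoro to methoxy, on an aromatic carbon para to a large group, is enough to produce a clear rise (an 8.5-fold higher number from compound 3 to compound 4 (0.93 log units; beyond the scatter)). Among the compounds shown here, that rise nearly covers the whole gap once seen with the dimethoxy compound: removing its second methoxy group gives a step within the scatter (a 1.3-fold lower number from compound 2 to compound 4 (0.10 log units; within the scatter)), and compound 4 also stands apart from the dichloro compound (a 6.5-fold higher number from compound 1 to compound 4 (0.81 log units; beyond the scatter)), so at this position the single 4-methoxybenzyl group already carries the loss, with no readable contribution from the second methoxy group. No measurement given here bears on what lies behind this difference.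

The compounds shown leave open whether the rise belongs to methoxy in particular or would also come with a hydroxyl, a methyl or an ethoxy group at this place. They also leave open where a plain unsubstituted benzyl group, or a benzyl group carrying a single chlorine, would fall relative to the 4-fluorobenzyl and 4-methoxybenzyl groups.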